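The source may hold more compounds than are shown below. What is called first, only, known or untested is meant among the compounds shown, and "the series" means these compounds.

In a functional assay on P388 cells (Mus musculus) for inhibition (on this read-out lower numbers stand for stronger inhibition and higher numbers for weaker inhibition), three compounds built on a shared core have been measured. Compound 1 `COCCOc1cc(/C=C/c2ccc3ccccc3c2)ccc1OC` gives 2990 nM, compound 2 `COc1ccc(/C=C/c2ccc3ccccc3c2)cc1F` gives 4490 nM, and compound 3 `CN(C)c1ccc(/C=C/c2ccc3ccccc3c2)cc1` gives 3660 nM. Among the measured compounds shown here, compound 2 thus stands within the usual scatter of both other compounds, and the numbers so far do not separate the three.

Compound 4 `CCN(CC)c1cc(/C=C/c2ccc3ccccc3c2)ccc1OC` has not yet been measured. It departs from compound 2 in one place, with diethylamino in place of fluoro on an aromatic carbon, ortho to a methoxy group and meta to a large group: diethylamino in place of fluoro on an aromatic carbon.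

For the measured compounds named here, only one measured step touches this place. That step, a 1.5-fold higher number from compound 1 to compound 2 (0.18 log units; within the scatter), exchanges 2-methoxyethoxy for fluoro and stays within the scatter. Going by the values given here, compound 3, which carries a dimethylamino group, lies just as close to compound 2, but no single-place step links the two. The data hold no measurement of a diethylamino group, so the expectation rests on this one small step and the range is kept wide. No change beyond the scatter is therefore expected in this assay. The expected step, a 1.3-fold lower number from compound 2 to compound 4 (0.11 log units; within the scatter), is estimated to remain within the scatter. For compound 4 the estimate is 3500 nM, with an expected range from 1500 nM to 8000 nM.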

Compound 4, half-maximal inhibitory concentration: > 5000 nM
Compound 4: only a limit was reported; the forecaster's own chance of this, stated with the estimate: 5%; middle value at least 1.4-fold (0.15 log units) from the limit.
By their numbers in this assay, from the lowest: compounds 1, 3 and 2 (each within the scatter of the next). At a limit, above all of these: compound 4.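

In this assay compound 4 is reported only as a limit: the limit of > 5000 nM in this assay, at which 1 of the 4 values shown sits.

Where the earlier compounds offered only an exchange of 2-methoxyethoxy and fluoro at this place, the result adds diethylamino, a group with nitrogen and more heavy atoms than either, and the reading is an at least 1.1-fold higher number from compound 2 to compound 4 (0.04 log units; that floor lies within the scatter) against fluoro and an at least 1.6-fold higher number from compound 1 to compound 4 (0.22 log units; that floor lies within the scatter) against 2-methoxyethoxy. Both of these steps are floors and give no true size, so the change may be small or may be much larger. What the result does show is that diethylamino on this aromatic carbon, ortho to a methoxy group, brings no stronger inhibition than fluoro or 2-methoxyethoxy at the same place in this assay.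

Going by these compounds, how far the number of compound 4 actually lies from those of the other compounds stays open, since a limit cannot settle whether either step goes beyond the scatter. Also open, on these data alone, is what a smaller amine such as a primary amine, or a carboxylic acid, would give on this same aromatic carbon, and whether any group there could lower the number at all.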